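A few compounds are considered here, and "the series" means these few. Any claim that something is new, unique, unknown or untested is made for them only; others in the source may bear on it.

Measured so far in a functional assay on SiHa cells (Homo sapiens) for inhibition, read by CCK-8 assay, with a stated time of 72 h, tested at 1 uM; on this read-out lower numbers stand for less inhibition of growth and higher numbers for more inhibition of growth at the one concentration tested:
- compound 1 `CN(C)C(=O)c1cc2cnc(Nc3ccc(NC(=O)C4(C(=O)Nc5ccc(Cl)cc5)CC4)cc3)nc2n1C1CCCC1`: -0.8%
- compound 2 `CN(C)C(=O)c1cc2cnc(Nc3ccc(NC(=O)C4(C(=O)Nc5ccccc5F)CC4)cc3)nc2n1C1CCCC1`: 63.4%
- compound 3 `CN(C)C(=O)c1cc2cnc(Nc3ccc(NC(=O)C4(C(=O)Nc5cccc(Cl)c5)CC4)cc3)nc2n1C1CCCC1`: 16.2%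

Of these three, compound 3 stands second highest, with 16.2%. Compound 4 `Cc1ccc(NC(=O)C2(C(=O)Nc3ccc(Nc4ncc5cc(C(=O)N(C)C)n(C6CCCC6)c5n4)cc3)CC2)cc1` changes one group: 4-methylphenyl in place of 3-chlorophenyl on an amide-type nitrogen. For the measured compounds named here, no measured compound carries 4-methylphenyl, so the nearest guide is compound 1, which also has a group named at the 4-position of the phenyl and gives -0.8%. The modest a number 17 percentage points higher from compound 1 to compound 3 (beyond the scatter) is the most relevant evidence. The large a number 47.2 percentage points lower from compound 2 to compound 3 (beyond the scatter) concerns 2-fluorophenyl and says less here. A small drop is therefore expected in this assay, probably not beyond the usual scatter. The expected change is a number 8.2 percentage points lower from compound 3 to compound 4 (within the scatter). For compound 4 the estimated value is 8%, with an expected range of -8% to 32%.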

Compound 4, percent growth inhibition at one concentration: 37%
Compound 4: the middle estimate sits 29 percentage points below what was measured; the measured number lies above the stated range.
By their numbers in this assay, from the lowest: compound 1; then compound 3; then compound 4; then compound 2.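

In this assay, the result shows that a group carried by the phenyl can decide the outcome even when the name differs only by methyl in place of chloro (a number 37.8 percentage points higher from compound 1 to compound 4 (beyond the scatter)). So 4-methylphenyl is not tied to the low number of 4-chlorophenyl: it stands above 3-chlorophenyl (a number 20.8 percentage points higher from compound 3 to compound 4 (beyond the scatter)) but below 2-fluorophenyl (a number 26.4 percentage points lower from compound 2 to compound 4 (beyond the scatter)). Nothing available explains these differences.

Still open, from the compounds shown here alone, is how 4-ethylphenyl or 4-methoxyphenyl would compare with 4-methylphenyl. Also open, going by these compounds, is whether 2-methylphenyl would reach the number of 2-fluorophenyl.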